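From 3-Methylphenyl to 2-Ethoxyphenyl: A Predicted Step

The source may report more compounds than this note shows. Statements on the series, on what has been measured and on what is new or still open speak of the compounds shown alone.

Of the compounds shown here, two have so far been tested in a functional assay on A549 cells (Homo sapiens) for antiproliferative activity, read by MTT assay, with a stated time of 48 h; a higher number here means a weaker inhibitor, a lower number a stronger inhibitor. Compound 1 `N#CC1=C(N)Oc2c(c3nc4ccccc4nc3c3ccccc23)C12C(=O)N(Cc1cnnn1-c1ccccc1Cl)c1ccccc12` gives 42600 nM, while compound 2 `Cc1cccc(-n2nncc2CN2C(=O)C3(C(C#N)=C(N)Oc4c(N)cc5nc6ccccc6nc5c43)c3ccccc32)c1` gives 12300 nM. Compound 2 therefore holds the lower of the two numbers, with compound 1 standing higher by a margin beyond the usual scatter.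

Compound 3 `CCOc1ccccc1-n1nncc1CN1C(=O)C2(C(C#N)=C(N)Oc3c(N)cc4nc5ccccc5nc4c32)c2ccccc21` has not yet been measured. Its change from compound 2 is 2-ethoxyphenyl in place of 3-methylphenyl on an aromatic nitrogen. Among the measured compounds shown here, no step between two measured compounds that differ at this one place is available, so the size of the effect cannot be read from the data and must be guessed. A modest shift, within or close to the scatter, is expected for the step of a 1.0-fold lower number from compound 2 to compound 3 (0.01 log units; within the scatter), with no strong reason to favour either direction. Compound 3 is therefore estimated to give 12000 nM in this assay, with a likely range from 4000 nM to 36000 nM.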

Compound 3, half-maximal inhibitory concentration: > 50000 nM
Compound 3 ended at the assay's limit; the forecaster's own chance of this, stated with the estimate: 5%; at least 4.1-fold (0.61 log units) between middle value and limit.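

In this assay compound 3 stands at a limit of the assay and not at a true number, so its step can be bounded from one side only: the limit of > 50000 nM in this assay, at which 1 of the 3 values shown sits. Even so, placing 2-ethoxyphenyl in place of 3-methylphenyl on the aromatic nitrogen gives an at least 4.0-fold higher number from compound 2 to compound 3 (0.60 log units; beyond the scatter), the first step available at this position. This position on the shared core is therefore not indifferent to the substituted phenyl group it carries, which the two earlier compounds, differing in more than one place, could not show.

The compounds shown leave open whether the ethoxy group itself or its place on the phenyl ring accounts for the step. A 2-methylphenyl or a 3-ethoxyphenyl group at the same nitrogen would separate these two readings.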